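A Carbamate Aryl Swap at the Bottom of the Series

The compounds below may be only part of what the source reports. "The series", "measured", "known", "first", "only" and "open" are said of these compounds alone.

Three compounds built on one shared core were tested in a functional assay on PANC-1 cells (Homo sapiens) for inhibition, read by MTT assay, with a stated time of 24 h, tested at 10 uM; a higher number here means more inhibition at the concentration tested (going by the name of the read-out), a lower number less inhibition. Compound 1 `CCOc1cc(=O)n(CCCO)c2c1CC(CC=C(C)C)C(C)(C)C2` gives 16.6%. Compound 2 `CC(C)=CCC1Cc2c(OCc3ccccc3)cc(=O)n(CCCO)c2CC1(C)C` gives 11.1%. Compound 3 `COc1ccccc1NC(=O)Oc1cc(=O)n(CCCO)c2c1CC(CC=C(C)C)C(C)(C)C2` gives 0%, which is the lowest of the three numbers, with compound 2 nearest and compound 1 furthest from it. The steps between them read as follows: a number 5.5 percentage points lower from compound 1 to compound 2 (within the scatter); a number 16.6 percentage points lower from compound 1 to compound 3 (beyond the scatter); a number 11.1 percentage points lower from compound 2 to compound 3 (beyond the scatter).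

Compound 4 `CC(C)=CCC1Cc2c(OC(=O)Nc3ccc(F)cc3F)cc(=O)n(CCCO)c2CC1(C)C` has not yet been measured in this assay. It differs from compound 3 in a single place: 2,4-difluorophenyl in place of 2-methoxyphenyl on an amide-type nitrogen. Among the measured compounds shown here, none of the measured steps touches the aryl group on the amide-type nitrogen; the two steps that end in compound 3 both change the group on the oxygen of the aromatic ring, and both run downward to the carbamate. They show that the carbamate-bearing compound sits at the floor of the set, but they give no guide to how exchanging 2-methoxyphenyl for 2,4-difluorophenyl would move the number. With compound 3 already at its floor, the step from compound 3 to compound 4 is expected to be a number 5 percentage points higher from compound 3 to compound 4 (within the scatter), a change estimated to stay within the scatter. Compound 4 is accordingly expected to give about 5%, in a range from 0% to 18%.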

Compound 4, a percentage reported as inhibition, at one concentration (the size of the read-out at that concentration, not a potency): 0%
Estimate against measurement, compound 4: 5 percentage points above; the range from low to high includes it.
By their numbers in this assay, from the lowest: compounds 3 and 4 (each within the scatter of the next); then compounds 2 and 1 (each within the scatter of the next).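

In this assay, the aryl group on the amide-type nitrogen now has a measured step: 2,4-difluorophenyl in place of 2-methoxyphenyl gives no change at the digits printed from compound 3 to compound 4 (within the scatter), so this exchange does not lift the number off zero. Among the compounds shown here, the earlier compounds showed the drop to the carbamate with only one aryl group, whereas it now appears with a second, as a number 11.1 percentage points lower from compound 2 to compound 4 (beyond the scatter) and a number 16.6 percentage points lower from compound 1 to compound 4 (beyond the scatter), the same in size as the steps that end in compound 3. Nothing in the data shown accounts for the low numbers of the two carbamates or for the absence of a difference between them.

As far as these compounds go, since compound 3 and compound 4 both read zero, the result cannot separate the two aryl groups, and it remains open whether the two would differ at another concentration or exposure time. Also open, from the compounds shown here alone, is whether a cyclohexyl group or a methyl group on the amide-type nitrogen, or a phenyl ring carrying an amine or a carboxylic acid, would give a number above zero.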